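The compounds below may be only part of what the source reports. "The series", "measured", "known", "first", "only" and "open" are said of these compounds alone.

Measured so far:
compound 1 `O=C1Nc2ccc([N+](=O)[O-])cc2/C1=N/NC(=S)N1CCN(c2ccccc2)CC1` with 23300 nM
compound 2 `Cc1ccccc1N1CCN(C(=S)N/N=C2\C(=O)Nc3ccc(Cl)cc32)CC1` with 10900 nM

Compound 2 holds the lowest of the two numbers in a functional assay on MCF7 cells (Homo sapiens) for inhibition, read by MTT assay, with a stated time of 72 h; on this read-out lower numbers stand for stronger inhibition and higher numbers for weaker inhibition. Compound 1 differs from compound 2 in more than one place, so its value only shows that its number sits beyond the scatter from that of compound 2, and nothing is known here about which part of the difference carries the gap.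

Compound 3 `O=C1Nc2ccc(Cl)cc2/C1=N/NC(=S)N1CCN(c2ccccc2[N+](=O)[O-])CC1` is not yet measured in this assay. It differs from compound 2 in one place: nitro in place of methyl on an aromatic carbon. For the measured compounds named here, no step between measured compounds covers this change, and the pair of compound 1 and compound 2 does not isolate it either. The step from compound 2 to compound 3 is expected to be small, in either direction, and most likely not beyond the scatter, as a 1.1-fold higher number from compound 2 to compound 3 (0.04 log units; within the scatter) states. Compound 3 is therefore expected to give 12000 nM, within a range of 5000 nM to 30000 nM.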

Compound 3, half-maximal inhibitory concentration: 7490 nM
Compound 3: the middle estimate sits 1.6-fold (0.20 log units) above what was measured; the measured number falls inside the stated range.
By their numbers in this assay, from the lowest: compounds 3 and 2 (each within the scatter of the next); then compound 1.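

Nitro in place of methyl on this aromatic carbon, ortho to a large group, gives the first one-place comparison in the series: in this assay it is a 1.5-fold lower number from compound 2 to compound 3 (0.16 log units; within the scatter) and so separates the two groups by nothing beyond the scatter. The 2-methylphenyl and 2-nitrophenyl forms therefore cannot be told apart on this read-out, even though nitro has more heavy atoms than methyl and carries hydrogen-bond acceptors that methyl lacks. Nothing available here explains why the two groups read alike.

Open, on these data alone, is whether an amine, a carboxylic acid or a longer chain on this aromatic carbon would also stay within the scatter of compound 2. Also open, as far as these compounds go, is how the gap to compound 1 divides among its differences, and whether this swap reads the same with a nitro group on the shared core in place of chlorine.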